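Working notes: trifluoromethyl in place of (trifluoromethyl)sulfanyl

The source may hold more compounds than are shown below. What is called first, only, known or untested is meant among the compounds shown, and "the series" means these compounds.

Of the compounds shown here, two have numbers so far. In a functional assay on HCT-116 cells (Homo sapiens) for inhibition, read by MTT assay, with a stated time of 72 h (a lower number here means a stronger inhibitor, a higher number a weaker inhibitor), compound 1 `NS(=O)(=O)c1ccc2c(c1)C(=O)C(=O)N2Cc1cccc(C(F)(F)F)c1` gives 30000 nM, and compound 2 `NS(=O)(=O)c1ccc2c(c1)C(=O)C(=O)N2Cc1ccc(SC(F)(F)F)cc1` gives 15000 nM. These two values lie within the scatter of each other, so they cannot be ranked, and compound 2 stands level with compound 1 on the present numbers.

The next compound to be read is compound 3 `NS(=O)(=O)c1ccc2c(c1)C(=O)C(=O)N2Cc1ccc(C(F)(F)F)cc1`. It carries trifluoromethyl in place of (trifluoromethyl)sulfanyl on an aromatic carbon, para to a large group: trifluoromethyl in place of (trifluoromethyl)sulfanyl on an aromatic carbon. The rest of the structure stays as in compound 2.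

Among the measured compounds shown here, no measured pair differs in one place only, so this change has no direct precedent and any expectation is loose. For the measured compounds named here, the only guide is that in this assay compound 1 sits at 30000 nM and compound 2 sits at 15000 nM, close together. No shift beyond the scatter is expected in either direction, and the estimated change is a 1.3-fold higher number from compound 2 to compound 3 (0.12 log units; within the scatter). The estimate for compound 3 is 20000 nM, with an expected range from 9000 nM to 45000 nM.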

Compound 3, half-maximal inhibitory concentration: 34000 nM
Compound 3: middle estimate off by 1.7-fold (0.23 log units), on the low side; measured number inside the range.
By their numbers in this assay, from the lowest: compounds 2, 1 and 3 (each within the scatter of the next, the first and the last beyond it).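

Among the compounds shown here, this is the first pair that differs in one place only, and it gives the change a direct reading: with trifluoromethyl in place of (trifluoromethyl)sulfanyl on the aromatic carbon para to a large group, this assay shows a 2.3-fold higher number from compound 2 to compound 3 (0.36 log units; beyond the scatter). The step lies just beyond the scatter and is modest, so this position responds to the swap of these two groups, but only weakly, and the sulfur-bearing group holds the lower number of the pair, with compound 2 at 15000 nM. It is a single pair on a single core, so it sets a direction for this one change and no wider trend, and nothing at hand bears on why the step has this size.

Open, as far as these compounds go, is whether a group of another kind at this place, such as an amine, a carboxylic acid or a longer alkyl chain, moves the number by more than this modest step. Also open, from the compounds shown here alone, is whether any change on the shared core brings the number far lower than that of compound 2.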